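Bromo for Vinyl: Expected Tolerance of Compound 3

This account rests on a few compounds, and the source may have more. Where it says the series, first, only, none or still open, it means among the compounds named here.

Measured compounds:
compound 1, `CCc1csc(CN[C@@H]2C[C@H]3C[C@@H]([C@H]2C)C3(C)C)c1`: 25000 nM
compound 2, `C=Cc1ccsc1CN[C@@H]1C[C@H]2C[C@@H]([C@H]1C)C2(C)C`: 50000 nM

Both compounds were examined in an ADME assay on MDCK cells (Canis lupus familiaris) for cytotoxicity, read by microscopy, with a stated time of 48 h; a higher number here means that more compound is tolerated, a lower number that less compound is tolerated. In this assay compound 2 gives 50000 nM, and compound 1 gives 25000 nM. Compound 2 holds the highest of the two numbers, yet its nearest neighbour, compound 1, lies within the scatter of it, so the two cannot be ranked against each other. Going by the values given here, no step between measured compounds that differ in one place is available.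

The unmeasured compound 3, `C[C@H]1[C@H](NCc2sccc2Br)C[C@H]2C[C@@H]1C2(C)C`, differs from compound 2 in one place: bromo in place of vinyl on an aromatic carbon. The change sits on an aromatic carbon of a five-membered aromatic ring with 1 sulfur, next to the ring atom that bears a large group, two ring bonds from the ring sulfur. Nothing measured here speaks to bromo in place of vinyl, and the two measured values stand within the scatter of each other, so no direction can be drawn from them.

The step of a 1.4-fold lower number from compound 2 to compound 3 (0.15 log units; within the scatter) is expected to stay within the scatter. For compound 3 the estimated value is 35000 nM, with a range from 12000 nM to 100000 nM.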

Compound 3, minimum cytotoxic concentration: 50000 nM
For compound 3 the middle estimate is 1.4-fold (0.15 log units) below the measured one; measured number inside the range.
By their numbers in this assay, from the lowest: compounds 1, 2 and 3 (each within the scatter of the next).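

In this assay bromo in place of vinyl on this aromatic carbon, two ring bonds from the ring sulfur, gives no change at the digits printed from compound 2 to compound 3 (within the scatter) and so offers the only direct reading of a single change among the compounds shown. At this position, the two-carbon vinyl group and the single bromine atom cannot be told apart in the tolerated concentration, something the earlier pair, which differs in more than one place, could not show. No measurement shown accounts for this outcome or links it to any property of either group.

Only vinyl and bromo have stood at this position among the compounds shown, so it remains open whether an amine, a carboxylic acid or a longer chain on the same aromatic carbon would give a value beyond the scatter. Going by these compounds, it also remains open whether bromo would give the same reading at other carbons of the ring.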